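The source may report more compounds than this note shows. Statements on the series, on what has been measured and on what is new or still open speak of the compounds shown alone.

Compound 1, `CC(/C=C/CC(C)CCCC(C)C)=C\C(=O)OC(C)C`, gives 7.15 in a physicochemical assay for lipophilicity; on this read-out lower numbers stand for lower lipophilicity and higher numbers for higher lipophilicity.
Compound 2, `CCNC(=O)OC(C)(C)CCCC(C)C/C=C/C(C)=C/C(=O)OC(C)C`, gives 6.06.
Compound 3, `CC(C)=CCCC(C)C/C=C/C(C)=C/C(=O)OC(C)C`, gives 6.6.

Among these three numbers compound 1 stands highest. The nearest neighbour is reached by a number 0.55 log units lower from compound 1 to compound 3 (beyond the scatter), the furthest by a number 1.09 log units lower from compound 1 to compound 2 (beyond the scatter). Compound 4, `CCNC(=O)/C=C(C)/C=C/CC(C)CCCC(C)C`, differs from compound 1 by ethylamino in place of isopropoxy on a carbonyl carbon. Neither measured step touches this spot: one alters a chain end four bonds from a double-bonded chain carbon, the other adds a group on a saturated chain carbon. Among the compounds with values here, both steps did lower the read-out, the first by a modest amount and the second by a large one, so a fall in this assay beyond the scatter is expected here too, though its size rests on no direct precedent. For compound 4 the expected value is 5.7, likely between 5 and 6.4. This estimate means a step of a number 1.45 log units lower from compound 1 to compound 4 (beyond the scatter).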

Compound 4, partition coefficient: 5.24
Beside the measured number, compound 4's estimate is 0.46 log units above it, and the stated range covers the measured number.
By their numbers in this assay, from the lowest: compound 4; then compound 2; then compound 3; then compound 1.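

Replacing isopropoxy with ethylamino on the carbonyl carbon, which turns isopropoxycarbonyl into ethylcarbamoyl, gives in this assay a number 1.91 log units lower from compound 1 to compound 4 (beyond the scatter). Within the data shown here, this shows that the read-out responds strongly to a change at this carbonyl carbon, a place the earlier steps left untouched. Which feature of the swap accounts for the step cannot be said from the information available.

Still open, as far as these compounds go, is how an ethoxy group or a carboxylic acid would read at this carbonyl carbon. An ethoxy group would help separate the exchange of oxygen for nitrogen from the change in the size of the group.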